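Methoxy in place of methyl: compound 2 to compound 3

The source may report more compounds than this note shows. Statements on the series, on what has been measured and on what is new or still open speak of the compounds shown alone.

Of the compounds shown here, two carry numbers so far, compound 1 `O=P(OCc1ccccc1)(OCc1ccccc1)[Se]c1ccccc1` and compound 2 `COP(=O)(OC)[Se]c1ccc(C)cc1`. In a functional assay, tested at 100 uM (a higher number here means a stronger effect of the compound at the concentration tested, a lower number a weaker effect), compound 1 gives 1.86%. In this assay compound 2 gives 29.9%, the higher of the two numbers, with compound 1 lower by a gap beyond the scatter. Compound 3 `COc1ccc([Se]P(=O)(OC)OC)cc1` is not yet measured; against compound 2 the change is methoxy in place of methyl on an aromatic carbon. Within the data shown here, no step between measured compounds shows this change, so its direction is open; a step in this assay within the scatter, in either direction, is expected. Compound 3 is expected at 30%, range 10% to 55%. This amounts to an expected step of a number 0.1 percentage points higher from compound 2 to compound 3 (within the scatter).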

Compound 3, a percentage reported as activity, at one concentration (the size of the read-out at that concentration, not a potency): 6.91%
The estimate for compound 3 lay 23.1 percentage points above the measured number; measured number below the stated range.
By their numbers in this assay, from the lowest: compounds 1 and 3 (each within the scatter of the next); then compound 2.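

On the shared core, the group on this aromatic carbon, para to a group of 7 heavy atoms, matters in this assay: methoxy in place of methyl gives a number 23 percentage points lower from compound 2 to compound 3 (beyond the scatter). Among these compounds, this is the first change read at a single place, and it shows that a methyl at this carbon cannot be swapped for methoxy without a loss of effect. Nothing on hand accounts for the step.

On these data alone, whether an amine or a chlorine atom at this carbon would behave like methyl or like methoxy remains open. So does whether an ethyl or a longer chain here would keep the number of compound 2.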